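The source may report more compounds than this note shows. Statements on the series, on what has been measured and on what is new or still open speak of the compounds shown alone.

Of the compounds shown here, two sharing one core have been measured in an assay on membranes from HeLa cells for displacement of a labelled ligand from adenosine receptor A3 (Homo sapiens), read by scintillation counting, with a stated time of 180 min, tested at 1 uM; a lower number here means less inhibition, a higher number more inhibition at the concentration tested (going by the name of the read-out). Compound 1 `CC1=C(C(=O)NC(C)C)C(c2ccco2)NC(=O)N1` gives 4%. Compound 2 `CC1=C(C(=O)SC(C)C)C(c2ccco2)NC(=O)N1` gives 1%. Going by the values given here, the single measured step, a number 3 percentage points lower from compound 1 to compound 2 (within the scatter), puts isopropylsulfanyl in place of isopropylamino on a carbonyl carbon. Compound 2 thus holds the lower of the two numbers, but its distance from compound 1 lies within the scatter, so neither compound can be placed above the other in this assay.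

Compound 3 `CCC(CC)OC(=O)C1=C(C)NC(=O)NC1c1ccco1` has not yet been measured. It differs from compound 2 by (pentan-3-yl)oxy in place of isopropylsulfanyl on a carbonyl carbon. Among the compounds with values here, only the step from compound 1 to compound 2 touches the same carbonyl carbon, and that step was small. With both measured compounds showing little inhibition in this assay, compound 3 is expected to show a step of a number 2 percentage points higher from compound 2 to compound 3 (within the scatter) that stays within the scatter. Compound 3 is therefore estimated at 3%, with a range from -8% to 15%.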

Compound 3, a percentage reported as inhibition, at one concentration (the size of the read-out at that concentration, not a potency): 1%
Estimate against measurement, compound 3: 2 percentage points above, and the stated range covers the measured number.
By their numbers in this assay, from the lowest: compounds 2, 3 and 1 (each within the scatter of the next).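

Placing (pentan-3-yl)oxy on a carbonyl carbon in this assay gives no change at the digits printed from compound 2 to compound 3 (within the scatter) and, with isopropylamino as the group replaced, a number 3 percentage points lower from compound 1 to compound 3 (within the scatter) at this same place. The earlier pair compared only a sulfur-linked and a nitrogen-linked group, whereas these steps add an oxygen-linked one, and going from 4 to 6 heavy atoms in the group that leaves and enters still yields no step beyond the scatter. No available evidence accounts for these readings.

With all three compounds this close at a single concentration, the compounds shown do not tell whether any group on this carbonyl carbon can raise the inhibition at all. A free carboxylic acid, a benzylamino group or a longer chain such as octyloxy in this place remains an open case.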